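This account rests on a few compounds, and the source may have more. Where it says the series, first, only, none or still open, it means among the compounds named here.

Measured compounds:
compound 1 `CN(C)CCCN(Cc1ccccc1)c1cccc(C(=O)N2CCc3ccc(OS(N)(=O)=O)cc3C2)c1` — 26%
compound 2 `CCN(Cc1cccc(Br)c1)c1cccc(C(=O)N2CCc3ccc(OS(N)(=O)=O)cc3C2)c1` — 24.9%
compound 3 `CCCN(CCC)c1cccc(C(=O)N2CCc3ccc(OS(N)(=O)=O)cc3C2)c1` — 54.8%

All three were run in an assay on HEK293 cells for inhibition of Steryl-sulfatase (Homo sapiens), tested at 1 uM; on this read-out lower numbers stand for a weaker effect and higher numbers for a stronger effect at the one concentration tested. Compound 3 stands highest of the three; compound 1 lies below it beyond the scatter, and compound 2 lies further below, also beyond the scatter. Among the compounds with values here, the one single-point step among the measured compounds is a number 29.9 percentage points higher from compound 2 to compound 3 (beyond the scatter), a modest rise when dipropylamino replaces (3-bromobenzyl)(ethyl)amino.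

Compound 4 `CCCN(Cc1ccccc1)c1cccc(C(=O)N2CCc3ccc(OS(N)(=O)=O)cc3C2)c1` has not yet been measured. It differs from compound 3 by phenyl in place of ethyl on a saturated chain carbon bound to a nitrogen on an aromatic ring, so that dipropylamino becomes benzyl(propyl)amino. The step from compound 2 to compound 3 bears on this directly, since compound 2 carries a 3-bromobenzyl group on the nitrogen and compound 3 none; the two benzyl-bearing compounds, compound 1 and compound 2, both sit well below compound 3. On that basis a drop is expected for compound 4, of roughly the size seen in the step from compound 2 to compound 3, though compound 4 keeps one propyl, which neither compound 1 nor compound 2 has, so the drop may be somewhat smaller.

The expected step is a number 22.8 percentage points lower from compound 3 to compound 4 (beyond the scatter). Compound 4 is therefore estimated at 32% in this assay, with a range from 18% to 48%.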

Compound 4, a percentage reported as inhibition, at one concentration (the size of the read-out at that concentration, not a potency): 67.4%
Beside the measured number, compound 4's estimate is 35.4 percentage points below it; measured number outside the range, above it.
By their numbers in this assay, from the lowest: compounds 2 and 1 (each within the scatter of the next); then compound 3; then compound 4.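

In this assay the change from dipropylamino to benzyl(propyl)amino gives a number 12.6 percentage points higher from compound 3 to compound 4 (beyond the scatter) and so shows that phenyl in place of ethyl at this saturated chain carbon is tolerated and raises the number, against the reading suggested by the earlier benzyl-bearing compounds. A benzyl on this nitrogen therefore does not by itself go with a low number, since hydrogen in place of dimethylamino at the end of the chain gives a number 41.4 percentage points higher from compound 1 to compound 4 (beyond the scatter) while the benzyl stays in place. The replacement of (3-bromobenzyl)(ethyl)amino by benzyl(propyl)amino gives a number 42.5 percentage points higher from compound 2 to compound 4 (beyond the scatter) and points to the other groups on this nitrogen, not the benzyl as such, as what separates the low and high numbers in this small set.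

No evidence on hand accounts for the rise with phenyl. Still open, as far as these compounds go, are how much of the last step belongs to the bromine and how much to propyl in place of ethyl, and how a phenethyl or pyridylmethyl group in place of benzyl would read at this nitrogen.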